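A few compounds are considered here, and "the series" means these few. Any claim that something is new, unique, unknown or untested is made for them only; others in the source may bear on it.

Compound 3 `CC1(C)[C@H]2CC[C@]1(C)N(Cc1cn(-c3ccccc3C#N)nn1)C(=O)C2` gives 180 nM in a functional assay on HepG2 cells (Homo sapiens) for inhibition, read by MTT assay, with a stated time of 24 h (a lower number here means a stronger inhibitor, a higher number a weaker inhibitor), the highest of the three numbers here, although it sits within the scatter of compound 2 `Cc1ccccc1-n1cc(CN2C(=O)C[C@@H]3CC[C@@]2(C)C3(C)C)nn1`, which gives 150 nM, and of compound 1 `CC1(C)[C@H]2CC[C@]1(C)N(Cc1cn(-c3ccc(Cl)cc3)nn1)C(=O)C2`, which gives 90 nM. Compound 4 `CC1(C)[C@H]2CC[C@]1(C)N(Cc1cn(-c3ccc(C#N)cc3)nn1)C(=O)C2` differs from compound 3 in one place: 4-cyanophenyl in place of 2-cyanophenyl on an aromatic nitrogen. Every step measured so far stays within the scatter: a 1.7-fold higher number from compound 1 to compound 2 (0.22 log units; within the scatter), a 2.0-fold higher number from compound 1 to compound 3 (0.30 log units; within the scatter) and a 1.2-fold higher number from compound 2 to compound 3 (0.08 log units; within the scatter). None of them moves a cyano group around the ring, but each swap of the aromatic group on that nitrogen changed little, and the expected step is a 1.2-fold lower number from compound 3 to compound 4 (0.08 log units; within the scatter), nothing beyond the scatter. Compound 4 is therefore estimated at 150 nM, with a range from 60 nM to 400 nM.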

Compound 4, half-maximal inhibitory concentration: 50 nM
Compound 4: the middle estimate sits 3.0-fold (0.48 log units) above what was measured; measured number outside the range, below it.
By their numbers in this assay, from the lowest: compounds 4, 1, 2 and 3 (each within the scatter of the next, the first and the last beyond it).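

Where the nitrile sits on the ring now matters: 4-cyanophenyl in place of 2-cyanophenyl gives a step beyond the scatter (a 3.6-fold lower number from compound 3 to compound 4 (0.56 log units; beyond the scatter)), the first such step in this series. Replacing 2-methylphenyl with 4-cyanophenyl also goes beyond it (a 3.0-fold lower number from compound 2 to compound 4 (0.48 log units; beyond the scatter)), while the remaining new step stays within it (a 1.8-fold lower number from compound 1 to compound 4 (0.26 log units; within the scatter)). No available evidence explains why the nitrile's location changes the number. Still open, on these data alone, is how an amine or a carboxylic acid would compare with the nitrile on this ring, and how a plain phenyl would compare with all of them.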